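Aryl exchange on a piperazine with flat adenosine binding

The source may hold more compounds than are shown below. What is called first, only, known or untested is meant among the compounds shown, and "the series" means these compounds.

Three compounds on a shared core were measured in an assay on CHO cells for displacement of a labelled ligand from adenosine receptor A3 (Homo sapiens), read by scintillation counting, with a stated time of 120 min, tested at 10 uM; on this read-out lower numbers stand for less inhibition and higher numbers for more inhibition at the one concentration tested (going by the name of the read-out). Compound 1 `Nc1scc(CN2CCN(c3ccc(F)cc3Cl)CC2)c1C(=O)c1ccc(Cl)cc1` gives 0%, compound 2 `Nc1scc(CN2CCN(c3ccc(Cl)cc3F)CC2)c1C(=O)c1ccc(Cl)cc1` gives 1%, and compound 3 `Nc1scc(CN2CCN(c3ccncc3)CC2)c1C(=O)c1ccc(Cl)cc1` gives 2%. Compound 3 thus holds the highest of the three numbers, yet the steps toward it are a number 2 percentage points higher from compound 1 to compound 3 (within the scatter) and a number 1 percentage points higher from compound 2 to compound 3 (within the scatter), so nothing separates it from the other two; the three aryl groups on the ring amine nitrogen make no difference that the assay can resolve.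

Compound 4 `Nc1scc(CN2CCN(c3ccc(F)c(F)c3)CC2)c1C(=O)c1ccc(Cl)cc1` continues this series: 3,4-difluorophenyl in place of pyridin-4-yl on an amine nitrogen in a ring. The relevant comparisons are the three measured steps, each within the scatter, including a number 1 percentage points higher from compound 1 to compound 2 (within the scatter), where two halogenated phenyl rings swapped their halogen pattern without effect. A phenyl ring bearing fluorine in both measured halogenated analogues gave essentially no inhibition, and compound 3 with pyridin-4-yl gave the same.

Compound 4 is therefore expected to show a number 1 percentage points lower from compound 3 to compound 4 (within the scatter), that is, no step beyond the scatter. The estimate for compound 4 in this assay is 1%, with a range from -6% to 10%.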

Compound 4, a percentage reported as inhibition, at one concentration (the size of the read-out at that concentration, not a potency): 1%
The estimate for compound 4 equals the measured number at the digits printed; the measured number falls inside the stated range.
By their numbers in this assay, from the lowest: compounds 1, 2, 4 and 3 (each within the scatter of the next).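

Replacing pyridin-4-yl with 3,4-difluorophenyl on the amine nitrogen in the ring removes the ring's hetero atom and its hydrogen-bond acceptor and brings in two fluorine atoms, yet in this assay the change amounts to a number 1 percentage points lower from compound 3 to compound 4 (within the scatter). Among these compounds, the comparisons with the chlorine-bearing rings give no change at the digits printed from compound 2 to compound 4 (within the scatter) and a number 1 percentage points higher from compound 1 to compound 4 (within the scatter), so a phenyl ring with fluorine alone also shows no step that the assay can resolve at this place. No evidence is available to explain this flat result.

From the compounds shown here alone, all four compounds give values close to zero at the one concentration tested, so what this position can contribute to inhibition remains unknown. Going by these compounds, whether an amine, a carboxylic acid or a longer chain on this nitrogen would give a different reading stays open.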